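This account rests on a few compounds, and the source may have more. Where it says the series, first, only, none or still open, it means among the compounds named here.

Measured compounds:
Compound 1, `C[Si](C)(C)C#Cc1cc(-c2nc3cc(F)ccc3s2)ccc1N` — 160 nM
Compound 2, `N#Cc1cc(-c2nc3ccc(F)cc3s2)ccc1N` — 820 nM
Compound 3, `N#Cc1cc(-c2nc3c(F)cccc3s2)ccc1N` — 180 nM

All three were tested in a functional assay on MCF7 cells (Homo sapiens) for inhibition, with a stated time of 72 h; a higher number here means a weaker inhibitor of growth, a lower number a stronger inhibitor of growth. Of the three numbers, compound 2 gives the highest, 820 nM, and both of the other two lie beyond the usual scatter from it, so compound 2 is the weakest growth inhibitor of this small set.

The next compound, compound 4, `C[Si](C)(C)C#Cc1cc(-c2nc3ccc(F)cc3s2)ccc1N`, is compound 2 with one change: a group of 6 heavy atoms (5 carbon, 1 silicon; no ring) in place of a group of 2 heavy atoms (1 carbon, 1 nitrogen; no ring), on an aromatic carbon. Among the measured compounds shown here, no pair of measured compounds differs by exactly this change, so its effect has not been seen directly. Compound 1 carries the same entering group, but with the fluorine sitting at a different place on the shared core, and in this assay compound 1 gives 160 nM. The cyano of compound 2 is kept in compound 3, again with the fluorine moved, and in this assay compound 3 gives 180 nM. Both lower numbers therefore come together with a moved fluorine, which compound 4 does not have, and the comparison is only indirect.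

The expectation is a step toward a lower number, of moderate size and probably beyond the scatter, a 2.1-fold lower number from compound 2 to compound 4 (0.31 log units; beyond the scatter). Compound 4 is thus estimated at 400 nM, with a range from 100 nM to 1600 nM.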

Compound 4, concentration for 50% growth inhibition: 680 nM
Beside the measured number, compound 4's estimate is 1.7-fold (0.23 log units) below it; the measured number falls inside the stated range.
By their numbers in this assay, from the lowest: compounds 1 and 3 (each within the scatter of the next); then compounds 4 and 2 (each within the scatter of the next).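

In this assay, replacing the cyano group on this aromatic carbon, ortho to an amino group, with the group of 6 heavy atoms (5 carbon, 1 silicon) gives a 1.2-fold lower number from compound 2 to compound 4 (0.08 log units; within the scatter). Among the compounds shown here, this is the first direct view of the change, and it shows that, with the fluorine placed as in compound 2, the two groups cannot be told apart in this assay even though they differ in size and in hydrogen-bond acceptor count. Nothing available here explains this close agreement.

Going by these compounds, with the same entering group, compound 4 gives 680 nM and compound 1, with the fluorine elsewhere on the shared core, gives 160 nM, so how far the fluorine's place governs growth inhibition, and whether it does so with every group on this carbon, remains open. Also open, on these data alone, is what groups of another kind on this carbon, such as an amine, a carboxylic acid or a longer alkyl chain, would do to the number, since a cyano group and the silicon-bearing group alone do not show how much this position tolerates.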